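A Bromophenyl Swap on the Chain of Compound 3

The source may report more compounds than this note shows. Statements on the series, on what has been measured and on what is new or still open speak of the compounds shown alone.

Three measured compounds share the core of compound 1 `Cc1ccc(CS/C(=C/c2ccc(C)s2)C(=O)c2ccc(Cl)cc2)cc1` and were tested in a functional assay on DU-145 cells (Homo sapiens) for inhibition, read by trypan blue exclusion, with a stated time of 96 h; a lower number here means a stronger inhibitor of growth, a higher number a weaker inhibitor of growth. Compound 1 gives 50000 nM. Compound 2 `O=C(/C(=C\c1ccc(Br)cc1)Sc1ccc(Br)cc1)c1ccc(Cl)cc1` gives 1000 nM, and compound 3 `COc1ccccc1/C=C(/SCc1ccc(C)cc1)C(=O)c1ccc(Cl)cc1` gives 10000 nM. Compound 3 therefore sits second highest of the three numbers: the step of a 5.0-fold lower number from compound 1 to compound 3 (0.70 log units; beyond the scatter) separates it from compound 1, while compound 2 stands a further, larger distance below it.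

The unmeasured compound 4 `Cc1ccc(CS/C(=C/c2ccc(Br)cc2)C(=O)c2ccc(Cl)cc2)cc1` differs from compound 3 in one place: 4-bromophenyl in place of 2-methoxyphenyl on a double-bonded chain carbon bound to a double-bonded chain carbon

For the measured compounds named here, only one measured step touches this position, the exchange of the group on that chain carbon, and it was modest: a 5.0-fold lower number from compound 1 to compound 3 (0.70 log units; beyond the scatter). Compound 2 also carries 4-bromophenyl at the same place, but it differs from compound 4 in a second place as well. The value of compound 2, 1000 nM, can therefore only hint that a bromophenyl there is compatible with a lower number. On this basis a modest downward step is expected, a 2.0-fold lower number from compound 3 to compound 4 (0.30 log units; within the scatter), though a result within the scatter would not surprise. Compound 4 is estimated at 5000 nM, with a range from 1000 nM to 20000 nM.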

Compound 4, concentration for 50% growth inhibition: 10000 nM
Compound 4: the middle estimate sits 2.0-fold (0.30 log units) below what was measured; measured number inside the range.
By their numbers in this assay, from the lowest: compound 2; then compounds 3 and 4 (each within the scatter of the next); then compound 1.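

In this assay, the exchange of 2-methoxyphenyl for 4-bromophenyl on a double-bonded chain carbon bound to a double-bonded chain carbon gives no change at the digits printed from compound 3 to compound 4 (within the scatter) and so does not separate these two groups, while replacing 5-methylthiophen-2-yl with 4-bromophenyl at the same place gives a 5.0-fold lower number from compound 1 to compound 4 (0.70 log units; beyond the scatter) and matches in size the earlier 5.0-fold lower number from compound 1 to compound 3 (0.70 log units; beyond the scatter). Among these three compounds, then, the clear difference lies between the 5-methylthiophen-2-yl group and either of the two phenyl groups, and the 4-bromophenyl group alone does not bring the number down to that of compound 2, since 4-methylbenzyl in place of 4-bromophenyl on a sulfur gives a 10-fold higher number from compound 2 to compound 4 (1.00 log units; beyond the scatter) and shows that the group on the sulfur also matters. Nothing at hand explains why these numbers move as they do.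

On these data alone, it remains open whether the 4-bromophenyl group on the sulfur would give a similar step with 2-methoxyphenyl on the chain carbon. Also open, as far as these compounds go, is how an aminophenyl or carboxyphenyl group on the chain carbon, or a longer chain on the sulfur, would behave in this assay on this core.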